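Moving a Methyl Between Chain Carbon and Nitrogen

The compounds below may be only part of what the source reports. "The series", "measured", "known", "first", "only" and "open" are said of these compounds alone.

Two compounds with the same core carrying two phenyl groups have been measured. In a functional assay (brain) for displacement of a labelled ligand, with Rattus norvegicus as the target (on this read-out lower numbers stand for stronger inhibition and higher numbers for weaker inhibition), compound 1 `CNC[C@H]1COC(c2ccccc2)(c2ccccc2)O1` gives 7300 nM. Going by the values given here, compound 2 `CN[C@@H](C)[C@H]1COC(c2ccccc2)(c2ccccc2)O1` gives 703 nM in this assay, the lowest of the two numbers, with compound 1 as its only neighbour and a clearly higher number. Among the compounds with values here, the single measured step, a 10-fold lower number from compound 1 to compound 2 (1.02 log units; beyond the scatter), is large and lies beyond the usual scatter.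

Compound 3 `CCNC[C@H]1COC(c2ccccc2)(c2ccccc2)O1` has not yet been measured. It differs from compound 2 in one place: (ethylamino)methyl in place of 1-(methylamino)ethyl on a saturated ring carbon. The same atoms are present, but the extra carbon now sits on the nitrogen rather than on the chain carbon, and the defined stereocentre disappears.

The step from compound 1 to compound 2 bears on this only in part, since it shows what a methyl on the chain carbon did, not what an ethyl on the nitrogen does. Compound 3 keeps the added carbon but loses it from the chain carbon, so part of that gain may be given back. Compound 3 is therefore expected to give about 2500 nM in this assay, within a range of 700 nM to 9000 nM. The expected step from compound 2 is a 3.6-fold higher number from compound 2 to compound 3 (0.55 log units; beyond the scatter), an estimate that stays between the two measured values.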

Compound 3, inhibition constant: 8400 nM
Estimate against measurement, compound 3: 3.4-fold (0.53 log units) below, and the stated range covers the measured number.
By their numbers in this assay, from the lowest: compound 2; then compounds 1 and 3 (each within the scatter of the next).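

In this assay, the same atoms give clearly different numbers depending on where the extra carbon sits: shifting it from the chain carbon to the nitrogen, so that (ethylamino)methyl replaces 1-(methylamino)ethyl and the defined stereocentre disappears, gives a 12-fold higher number from compound 2 to compound 3 (1.08 log units; beyond the scatter) as the result. Lengthening the group on the nitrogen from methyl to ethyl leaves no readable difference on the shared core (a 1.2-fold higher number from compound 1 to compound 3 (0.06 log units; within the scatter)), so among these three compounds only compound 2, with its methyl on the chain carbon, stands apart from the other two. Nothing available here gives a reason for this difference between the two positions.

The compounds shown leave open whether the lower number of compound 2 depends on the particular arrangement at its defined stereocentre, as only one arrangement appears here. They also leave open what an ethyl on the chain carbon or a longer chain such as propyl on the nitrogen would do, and whether a primary amine, with no group on the nitrogen, would keep the gain seen with the chain methyl.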